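Losing a decyl chain from compound 1

The source may hold more compounds than are shown below. What is called first, only, known or untested is meant among the compounds shown, and "the series" means these compounds.

Measured in an ADME assay on NIH3T3 cells (Mus musculus) for cytotoxicity, read by neutral red uptake, with a stated time of 48 h; on this read-out lower numbers stand for higher toxicity in this test and higher numbers for lower toxicity in this test:
compound 1 `CCCCCCCCCCc1c(C)c(CCCCCCCCCC)c2[n+](c1C)CCC2`: 2.8 uM
compound 2 `CCCCCCCC/C=C\c1c(C)c(/C=C\CCCCCCCC)c2[n+](c1C)CCC2`: 22.7 uM

Compound 1, at 2.8 uM, holds the lower of the two numbers in this assay, and compound 2 gives 22.7 uM, a gap that lies beyond the scatter. Compound 3 `CCCCCCCCCCc1c(C)cc2[n+](c1C)CCC2` has hydrogen in place of decyl on an aromatic carbon. Within the data shown here, no measured pair shows this change, so the size of the step is a judgement. A move to a higher number, beyond the scatter, is expected in this assay. The expected step is an 11-fold higher number from compound 1 to compound 3 (1.03 log units; beyond the scatter). The estimate for compound 3 is 30 uM, with an expected range of 8 uM to 110 uM.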

Compound 3, half-maximal toxic concentration: 7 uM
Compound 3: middle estimate off by 4.3-fold (0.63 log units), on the high side; measured number below the stated range.
By their numbers in this assay, from the lowest: compound 1; then compound 3; then compound 2.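

In this assay, hydrogen in place of decyl on this aromatic carbon gives a 2.5-fold higher number from compound 1 to compound 3 (0.40 log units; beyond the scatter), a modest step that shows this position registers the change. Compound 3, which keeps its other decyl group, still gives 7 uM, so losing this chain does not remove the toxicity in this test. Nothing available explains the size of this step. On these data alone, what a shorter chain such as butyl, or an amine, would do on this aromatic carbon remains open. So does the effect of also replacing the remaining decyl group with hydrogen.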